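This account rests on a few compounds, and the source may have more. Where it says the series, first, only, none or still open, it means among the compounds named here.

In an ADME assay on KB cells (Homo sapiens) for cytotoxicity, read by MTT assay, with a stated time of 72 h (a lower number here means that less compound is tolerated, a higher number that more compound is tolerated), compound 1 `COc1ccnc(-c2csc(Nc3ccc(Cl)cn3)n2)c1` gives 62800 nM. Compound 2 `COc1ccnc(-c2nc(Nc3ccc(Cl)cn3)sc2Cl)c1` carries chloro in place of hydrogen on an aromatic carbon and in this assay compound 2 gives 15000 nM; the step is a 4.2-fold lower number from compound 1 to compound 2 (0.62 log units; beyond the scatter). Compound 3 `Clc1ccc(Nc2nc(-c3ncccn3)cs2)nc1` has a different core; the difference between the two cores is not broken down here. In this assay compound 3 gives 20700 nM, a number within the scatter of that of compound 2. Compound 4 `Clc1ccc(Nc2nc(-c3ncccn3)c(Cl)s2)nc1` is not yet measured; it differs from compound 3 by chloro in place of hydrogen on an aromatic carbon, the same kind of change as that made from compound 1 to compound 2, though here the entering chloro sits next to the ring atom that bears a pyrimidin-2-yl group rather than a group of 8 heavy atoms. Because the same kind of change gave a 4.2-fold lower number from compound 1 to compound 2 (0.62 log units; beyond the scatter), a step of a 3.0-fold lower number from compound 3 to compound 4 (0.47 log units; beyond the scatter) is expected. Compound 4 is thus expected to give an estimated 7000 nM, with a likely range from 3000 nM to 20000 nM.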

Compound 4, half-maximal cytotoxic concentration: 66100 nM
Estimate against measurement, compound 4: 9.4-fold (0.98 log units) below, outside the stated range (above it).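

Chloro in place of hydrogen on the aromatic carbon next to the ring sulfur gives, in this assay, a 3.2-fold higher number from compound 3 to compound 4 (0.50 log units; beyond the scatter). The same change therefore moves the number in opposite directions on the two cores, so its effect on one core cannot simply be carried over to the other: the same change on two cores in this assay, a 4.2-fold lower number (0.62 log units; beyond the scatter) from compound 1 to compound 2 and a 3.2-fold higher number (0.50 log units; beyond the scatter) from compound 3 to compound 4, 13-fold (1.13 log units) apart, beyond the scatter of two such steps. These two pairs do not show which part of the cores causes the split, nor how the change would behave on any third core.

From the compounds shown here alone, it remains open whether a methyl or a fluoro on that same carbon would also separate the two cores. Going by these compounds, it is equally open whether an amine there would do so.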